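Three Stereoisomers Measured, a Fourth Estimated

The compounds below may be only part of what the source reports. "The series", "measured", "known", "first", "only" and "open" are said of these compounds alone.

Compound 1 `O=C(O)[C@H]1NC[C@H](O)[C@H](O)[C@H]1O`, compound 2 `O=C(O)[C@H]1NC[C@H](O)[C@@H](O)[C@@H]1O` and compound 3 `O=C(O)[C@H]1NC[C@@H](O)[C@H](O)[C@@H]1O` share every atom and bond and differ only in configuration. In an assay on isolated protein for inhibition of cytosolic endo-beta-N-acetylglucosaminidase (Homo sapiens), tested at 1000 uM (a higher number here means more inhibition at the concentration tested (going by the name of the read-out), a lower number less inhibition), compound 1 gives 7.6%, compound 2 gives 43% and compound 3 gives 42%, so compound 3 stands second highest of the three, with compound 2 nearest and compound 1 furthest away. The step of a number 34.4 percentage points higher from compound 1 to compound 3 (beyond the scatter) shows how much configuration alone can move this assay, whereas a number 1 percentage points lower from compound 2 to compound 3 (within the scatter) shows it can also move nothing. Compound 4 `O=C(O)[C@@H]1NC[C@H](O)[C@@H](O)[C@@H]1O` differs from compound 3 as follows: the two compounds have the same atoms and bonds and differ only in configuration as drawn: 3 of 4 stereo elements differ; a stereocentre at a saturated ring carbon is drawn S in compound 3 and R in compound 4; a stereocentre at a saturated ring carbon is drawn R in compound 3 and S in compound 4; a stereocentre at a saturated ring carbon is drawn S in compound 3 and R in compound 4. Because the fact that compounds 1 and 3 differ only in the configuration as drawn and the fact that compounds 2 and 3 differ only in the configuration as drawn leave both outcomes open, a downward step is expected as more likely, giving a number 22 percentage points lower from compound 3 to compound 4 (beyond the scatter). Compound 4 is therefore estimated at 20%, within 3% to 45%.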

Compound 4, a percentage reported as inhibition, at one concentration (the size of the read-out at that concentration, not a potency): 5.4%
Compound 4: the middle estimate sits 14.6 percentage points above what was measured; the measured number falls inside the stated range.
By their numbers in this assay, from the lowest: compounds 4 and 1 (each within the scatter of the next); then compounds 3 and 2 (each within the scatter of the next).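

A single stereocentre can carry the whole difference in this assay: only one of four stereo elements changes in the step of a number 37.6 percentage points lower from compound 2 to compound 4 (beyond the scatter). The number of changed stereo elements does not settle the outcome, since three of four change both in the step of a number 36.6 percentage points lower from compound 3 to compound 4 (beyond the scatter) and in the step of a number 2.2 percentage points lower from compound 1 to compound 4 (within the scatter). Only the first of these two steps lies beyond the scatter.

The other stereo elements are not seen changing one at a time in these compounds. On these data alone, whether an amide or a hydroxymethyl group in place of the carboxylic acid would keep the inhibition also stays open.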